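A Benzyl Group Replaces Methoxyphenoxy on the Shared Core

The source may report more compounds than this note shows. Statements on the series, on what has been measured and on what is new or still open speak of the compounds shown alone.

Of the compounds shown here, three have so far been measured in a physicochemical assay for acid dissociation. Compound 1 `COc1cccc(CNCCCNc2ccnc3cc(Cc4ccccc4)ccc23)c1O` gives 9.47. Compound 2 `COc1ccc(-c2ccc3c(NCCCNCc4ccco4)ccnc3c2)cc1` gives 9.47. Compound 3 `COc1cccc(Oc2ccc3c(NCCCNCc4ccco4)ccnc3c2)c1` gives 9.28, the lowest of the three numbers, though its gap to each of the other two lies within the scatter, so none of the three can be set apart from the others.

Compound 4 `c1ccc(Cc2ccc3c(NCCCNCc4ccco4)ccnc3c2)cc1` has not yet been measured. It differs from compound 3 in one place: benzyl in place of 3-methoxyphenoxy on an aromatic carbon. Among the measured compounds shown here, no measured step swaps exactly these two groups. For the measured compounds named here, the one single-point step available, a number 0.19 log units lower from compound 2 to compound 3 (within the scatter), shows that exchanging the group at this position of the core moved the number very little. Compound 1 also carries a benzyl group and its value sits within the scatter of compound 3. The step of a number 0.17 log units higher from compound 3 to compound 4 (within the scatter) is therefore expected to be small, with no movement beyond the scatter. Compound 4 is estimated at 9.45, expected to fall between 9.15 and 9.75.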

Compound 4, acid dissociation constant: 9.47
The estimate for compound 4 lay 0.02 log units below the measured number; measured number inside the range.
By their numbers in this assay, from the lowest: compounds 3, 1, 2 and 4 (each within the scatter of the next).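

In this assay, benzyl in place of 3-methoxyphenoxy on this aromatic carbon gives a number 0.19 log units higher from compound 3 to compound 4 (within the scatter) and thus shows that a group with 0 hydrogen-bond acceptors cannot be told apart here from one with 2 hydrogen-bond acceptors. Benzyl in place of 4-methoxyphenyl at the same place gives no change at the digits printed from compound 2 to compound 4 (within the scatter) and so extends this to all three groups seen on this carbon, whether they have an oxygen in the link to the core, on the outer ring or, in benzyl, nowhere. A change at a second place, furan-2-yl in place of 2-hydroxy-3-methoxyphenyl on a saturated chain carbon bound to an amine nitrogen, gives no change at the digits printed from compound 1 to compound 4 (within the scatter) and likewise stays inside the scatter.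

From the compounds shown here alone, whether an amine or a carboxylic acid on this aromatic carbon would move the number beyond the scatter remains open. No measurement shown tells what sets this number in these compounds.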